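A few compounds are considered here, and "the series" means these few. Any claim that something is new, unique, unknown or untested is made for them only; others in the source may bear on it.

Measured compounds in the series:

- Compound 1 `COc1ccc(-c2c(Nc3ccc(F)cc3)c3ccc(OC)cc3oc2=O)cc1`: "not determined" (no result reported)
- Compound 2 `COc1ccc(-c2c(Nc3ccc(C)cc3)c3ccc(OC)cc3oc2=O)cc1`: 76500 nM
- Compound 3 `COc1ccc(-c2c(Nc3ccc(NC(C)=O)cc3)c3ccc(OC)cc3oc2=O)cc1`: "not determined" (no result reported)

Compound 1 carries no single number in a functional assay on PANC-1 cells (Homo sapiens) for antiproliferative activity, read by MTT assay, with a stated time of 48 h; on this read-out higher numbers stand for weaker inhibition and lower numbers for stronger inhibition: the entry stands without a result, as does the entry for compound 3. The only figure the series gives is that of compound 2, which in this assay gives 76500 nM, a weak inhibition. Compound 1 therefore cannot be placed against compound 2 on numbers; its two neighbours differ from it only in the substituent on the anilino ring, and nothing is recorded for that comparison.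

Compound 4 `COc1ccc2c(Nc3ccc(F)cc3)c(C(=O)C(F)(F)F)c(=O)oc2c1` remains to be measured. It differs from compound 1 as follows: (trifluoromethyl)carbonyl in place of 4-methoxyphenyl on an aromatic carbon. For the measured compounds named here, no step between measured compounds is available to calibrate this change, so the size of the move in this assay is open; the one measured value of the series sits in the weak range, and the shared core is kept. Compound 4 is expected to give 30000 nM, with a broad range from 4000 nM to 150000 nM.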

Compound 4, half-maximal inhibitory concentration: 12200 nM
The estimate for compound 4 lay 2.5-fold (0.39 log units) above the measured number; the measured number falls inside the stated range.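

For the compounds shown here, compound 4 gives 12200 nM in this assay, but compound 1 carries no number there, so no step between compound 1 and compound 4 can be read. On these data alone, what (trifluoromethyl)carbonyl in place of 4-methoxyphenyl does to inhibition stays open. No supporting evidence bears on this result.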